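Swapping a methylthiazole for a cyclopropyl oxazole

The compounds below may be only part of what the source reports. "The series", "measured", "known", "first", "only" and "open" are said of these compounds alone.

Two compounds share a bicyclic core and differ in the side group and the amide. Compound 1 `CNC(=O)c1ccc([C@H](C(=O)NC(C)C)N2C(=O)[C@@H](C3Cc4ccccc4C3)NC(=O)[C@H]2CC(C)C)o1` gives 39.8 nM in an assay on isolated protein for binding affinity to Oxytocin receptor (Homo sapiens); on this read-out higher numbers stand for weaker inhibition and lower numbers for stronger inhibition. Compound 2 `Cc1nc([C@H](C(=O)N(C)C)N2C(=O)[C@@H](C3Cc4ccccc4C3)NC(=O)[C@H]2CC(C)C)cs1` gives 0.398 nM in this assay, the lower of the two numbers, with compound 1 standing far above it, well beyond the scatter. Compound 3 `CC(C)C[C@@H]1C(=O)N[C@H](C2Cc3ccccc3C2)C(=O)N1[C@@H](C(=O)N(C)C)c1coc(C2CC2)n1` keeps the core and the dimethylamide of compound 2 and differs from it in one place: 2-cyclopropyl-1,3-oxazol-4-yl in place of 2-methyl-1,3-thiazol-4-yl on a saturated chain carbon bound to an amide-type nitrogen in a ring and a carbonyl carbon. Within the data shown here, no pair of measured compounds shows this change, so there is no directly measured step to lean on. Since both groups carry the same count of acceptors on a five-membered aromatic ring, a step that stays within the scatter of compound 2 is expected, with a slight lean toward a higher number from the larger group. The step from compound 2 to compound 3 is estimated at a 1.5-fold higher number from compound 2 to compound 3 (0.18 log units; within the scatter). Compound 3 is therefore expected to give 0.6 nM in this assay, within a range from 0.15 nM to 2.5 nM.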

Compound 3, inhibition constant: 0.794 nM
The estimate for compound 3 lay 1.3-fold (0.12 log units) below the measured number, and the stated range covers the measured number.
By their numbers in this assay, from the lowest: compounds 2 and 3 (each within the scatter of the next); then compound 1.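

In this assay, the saturated chain carbon bound to an amide-type nitrogen in a ring and a carbonyl carbon carries 2-cyclopropyl-1,3-oxazol-4-yl in place of 2-methyl-1,3-thiazol-4-yl with a 2.0-fold higher number from compound 2 to compound 3 (0.30 log units; within the scatter), so the larger group leaves the number within the scatter. This is the first comparison shown that differs in one place, since compound 1 differs from compound 2 in both the side group and the amide. No measurement at hand explains the size of this step.

Going by these compounds, the swap changes the ring and its substituent together, so what a 2-methyl-1,3-oxazol-4-yl or a 2-cyclopropyl-1,3-thiazol-4-yl group would give remains open. On these data alone, how this position would respond to an amine or a carboxylic acid on the ring also remains open.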